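This account rests on a few compounds, and the source may have more. Where it says the series, first, only, none or still open, it means among the compounds named here.

Compound 3 `CCC(=O)Nc1ccc(C2=NC(=O)/C(=C/c3ccc(OC)cc3)S2)cc1` gives 1840 nM in an assay on cells for inhibition of Polyunsaturated fatty acid 5-lipoxygenase (Homo sapiens), read by HPLC, with stated times of 15 min and 10 min (a higher number here means a weaker inhibitor, a lower number a stronger inhibitor), the highest number among the three measured compounds. Its nearest neighbour, compound 2 `COc1ccc(C2=NC(=O)/C(=C/c3cc4ccccc4[nH]3)S2)cc1`, gives 670 nM in this assay, and the strongest of the three, compound 1 `COc1ccc(/C=C2\SC(c3ccc(NC(=O)CCc4ccccc4)cc3)=NC2=O)cc1`, gives 260 nM in this assay. Among the measured compounds shown here, the one single-change step measured is a 7.1-fold higher number from compound 1 to compound 3 (0.85 log units; beyond the scatter), so the aromatic ring at the end of that side chain accounts for a clear part of the potency of compound 1.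

Compound 4 `COc1ccc(/C=C2\SC(c3ccc(C(=O)c4ccccc4)cc3)=NC2=O)cc1` differs from compound 3 by benzoyl in place of propanoylamino on an aromatic carbon. The change returns an aromatic ring to this position, though attached through a carbonyl rather than at the end of a saturated chain, and the amide hydrogen-bond donor of compound 3 is gone. For the measured compounds named here, no measured step tests a benzoyl directly, so the step from compound 1 to compound 3 is the only guide, and it points towards a lower number. Compound 4 is therefore expected to show a 3.7-fold lower number from compound 3 to compound 4 (0.57 log units; beyond the scatter) in this assay. Compound 4 is estimated at 500 nM, with a range from 150 nM to 1800 nM.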

Compound 4, half-maximal inhibitory concentration: 440 nM
Estimate against measurement, compound 4: 1.1-fold (0.06 log units) above, within the range that was stated.
By their numbers in this assay, from the lowest: compounds 1, 4 and 2 (each within the scatter of the next, the first and the last beyond it); then compound 3.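

Benzoyl in place of propanoylamino gives a 4.2-fold lower number from compound 3 to compound 4 (0.62 log units; beyond the scatter) in this assay, so this position, on an aromatic carbon para to a large group, accepts a change of linker as well as of size. Compound 4 has no hydrogen-bond donor in the entering group, yet its value lies within the scatter of that of compound 1, so the amide hydrogen is not needed to reach that range. With the earlier step, a 7.1-fold higher number from compound 1 to compound 3 (0.85 log units; beyond the scatter), two groups carrying a six-membered aromatic ring give lower numbers than propanoylamino, one with the ring joined through a carbonyl and one with it at the end of a saturated chain.

Nothing available bears on the reason for these steps. Still open, from the compounds shown here alone, is whether the aromatic ring alone suffices or the carbonyl also contributes, which a benzyl group at this position would separate. Also open, going by these compounds, is how a carboxylic acid or an amine on that ring would read.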